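The source may hold more compounds than are shown below. What is called first, only, known or untested is meant among the compounds shown, and "the series" means these compounds.

Working notes on the series

The three measured compounds share one core. Compound 1 is `Cn1c(CN2CCN(c3ncc(C(F)(F)F)cc3Cl)CC2)nc2ccccc21`, compound 2 is `Cn1c(CN2CCN(c3ccccc3F)CC2)nc2ccccc21` and compound 3 is `Cn1c(CN2CCC(c3ccccc3)CC2)nc2ccccc21`. In an assay on CHO cells with metabotropic glutamate receptor 2 (Homo sapiens) as the target, read by FLIPR (a lower number here means a smaller maximal response, a higher number a larger maximal response), compound 1 gives 71%, compound 2 gives 64% and compound 3 gives 89%. Compound 3 stands highest of the three maximal responses; compound 1 comes nearest and compound 2 lies furthest, and both gaps are beyond the scatter. Compound 1 and compound 2 each differ from compound 3 in more than one place, so no single step can be read from them; their numbers only show where each stands.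

Compound 4, `Cn1c(CN2CCC(c3ccccc3F)CC2)nc2ccccc21`, is not yet measured in this assay. It differs from compound 3 by fluoro in place of hydrogen on an aromatic carbon. Going by the values given here, no measured pair carries this change alone, so its size is open. Compound 2 also carries fluoro on its ring and gives 64%, but its other difference from compound 3 cannot be separated out. The expectation is a small step downward or none beyond the scatter. Compound 4 is estimated at 82%, within 65% to 95%. The expected step is a number 7 percentage points lower from compound 3 to compound 4 (within the scatter).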

Compound 4, largest response reached (Emax), in percent of the reference or control that the assay uses: 91%
Compound 4: the middle estimate sits 9 percentage points below what was measured; low and high end bracket the measured number.
By their numbers in this assay, from the lowest: compounds 2 and 1 (each within the scatter of the next); then compounds 3 and 4 (each within the scatter of the next).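

Fluoro in place of hydrogen on an aromatic carbon, ortho to a large group, gives a number 2 percentage points higher from compound 3 to compound 4 (within the scatter) in this assay, the first step in the series that can be read for a single change. Going by these compounds alone, compounds 1 and 2 offered no pair of this kind, so the effect of this change remained unknown until now; at this place, phenyl to 2-fluorophenyl does not separate compound 4 from compound 3 in maximal response, and the high response seen for compound 3 is kept with fluoro present. No measurement at hand bears on the reason for this outcome.

On these data alone, it remains open whether this place accepts groups other than fluoro in the same way, for example chloro, methoxy, an amine or a carboxylic acid, since a single fluoro samples only one small substituent at one place on the ring. Also open, as far as these compounds go, is whether the change from hydrogen to fluoro gives a step of similar size elsewhere on this ring, or on the ring of compound 2, where the rest of the molecule differs.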